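Changing the amine group on a sulfone series

This account rests on a few compounds, and the source may have more. Where it says the series, first, only, none or still open, it means among the compounds named here.

- Compound 1 `Cc1ccc(S(=O)(=O)c2cc3cnc(Nc4ccc5cc[nH]c5c4)nc3n(C)c2=O)cc1` gives 15000 nM
- Compound 2 `Cc1ccc(S(=O)(=O)c2cc3cnc(Nc4ccc5[nH]ccc5c4)nc3n(C)c2=O)cc1` gives 750 nM

In a functional assay on K562 cells (Homo sapiens) for inhibition, read by trypan blue exclusion, with a stated time of 72 h (a higher number here means a weaker inhibitor, a lower number a stronger inhibitor), compound 2 has the lower of the two numbers, 750 nM, which makes it the stronger inhibitor of this pair. The next compound to be measured is compound 3 `Cc1ccc(S(=O)(=O)c2cc3cnc(Nc4cccc5cccnc45)nc3n(C)c2=O)cc1`, which carries quinolin-8-yl in place of 1H-indol-5-yl on a nitrogen on an aromatic ring. Among the compounds with values here, only one measured step bears on this place, and it is large: a 20-fold lower number from compound 1 to compound 2 (1.30 log units; beyond the scatter). It shows that a change here can move the number a long way. Within the data shown here, the only other group measured here, in compound 1, gave 15000 nM, so a higher number is expected in this assay. The expected change is a clear weakening, a 6.7-fold higher number from compound 2 to compound 3 (0.82 log units; beyond the scatter). For compound 3 the estimated value is 5000 nM, with an expected range of 1200 nM to 20000 nM.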

Compound 3, half-maximal inhibitory concentration: 10000 nM
The estimate for compound 3 lay 2.0-fold (0.30 log units) below the measured number, within the range that was stated.
By their numbers in this assay, from the lowest: compound 2; then compounds 3 and 1 (each within the scatter of the next).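

In this assay the change from 1H-indol-5-yl to quinolin-8-yl gives a 13-fold higher number from compound 2 to compound 3 (1.12 log units; beyond the scatter) and so shows that a second, quite different group on this nitrogen also falls well short of compound 2. The other new step, a 1.5-fold lower number from compound 1 to compound 3 (0.18 log units; within the scatter), lies within the scatter, so compound 1 and compound 3 cannot be told apart, and among these three groups only the 1H-indol-5-yl of compound 2 stands out. No supporting data bear on why this group differs from the other two.

The swap to quinolin-8-yl alters the ring, the hydrogen-bond donor and the hydrogen-bond acceptor all at once, so the compounds shown cannot say which of these changes matters. On these data alone, whether a plain phenyl or a 1H-indazol-5-yl group on this nitrogen would match compound 2 remains open.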